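Quinoline carboxamides: aryl swap on a pyrrolidine-bearing analogue

This account rests on a few compounds, and the source may have more. Where it says the series, first, only, none or still open, it means among the compounds named here.

Compound 1 `COc1cccc(-c2cc(C(=O)Nc3ccc(Oc4ccnc5cc(OCCCN6CCCCC6)c(OC)cc45)c(F)c3)c3ccccc3n2)c1`: 380 nM
Compound 2 `COc1cc2c(Oc3ccc(NC(=O)c4cc(-c5ccc(Cl)c(Cl)c5)nc5ccccc45)cc3F)ccnc2cc1OCCCN1CCCCC1`: 770 nM
Compound 3 `COc1cc2c(Oc3ccc(NC(=O)c4cc(-c5ccc(Cl)c(Cl)c5)nc5ccccc45)cc3F)ccnc2cc1OCCCN1CCCC1`: 340 nM

In a functional assay on SMMC-7721 cells (Homo sapiens) for cytotoxicity, read by MTT assay, with a stated time of 72 h (on this read-out lower numbers stand for stronger inhibition and higher numbers for weaker inhibition), compound 3 gives the lowest number of the three, though its gap to compound 1 is within the scatter; only compound 2 is clearly weaker. Compound 4 `COc1cccc(-c2cc(C(=O)Nc3ccc(Oc4ccnc5cc(OCCCN6CCCC6)c(OC)cc45)c(F)c3)c3ccccc3n2)c1` differs from compound 3 by 3-methoxyphenyl in place of 3,4-dichlorophenyl on an aromatic carbon. This reverses the aryl change seen in a 2.0-fold higher number from compound 1 to compound 2 (0.31 log units; beyond the scatter), which was modest but beyond the scatter. The other step, a 2.3-fold lower number from compound 2 to compound 3 (0.36 log units; beyond the scatter), suggests the pyrrolidine chain amine keeps the aryl effect intact. A modest step toward a lower number is therefore expected, a 2.0-fold lower number from compound 3 to compound 4 (0.30 log units; within the scatter). Compound 4 is estimated at 170 nM, with a range from 80 nM to 400 nM.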

Compound 4, half-maximal inhibitory concentration: 790 nM
Estimate against measurement, compound 4: 4.6-fold (0.67 log units) below; measured number above the stated range.
By their numbers in this assay, from the lowest: compounds 3 and 1 (each within the scatter of the next); then compounds 2 and 4 (each within the scatter of the next).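

In this assay, a 2.3-fold higher number from compound 3 to compound 4 (0.37 log units; beyond the scatter) shows that the 3-methoxyphenyl group on the aromatic carbon next to the ring nitrogen does not give the same result with the pyrrolidin-1-yl chain as with the piperidin-1-yl chain: the same change on two cores in this assay, a 2.0-fold higher number (0.31 log units; beyond the scatter) from compound 1 to compound 2 and a 2.3-fold lower number (0.37 log units; beyond the scatter) from compound 4 to compound 3, 4.7-fold (0.67 log units) apart, beyond the scatter of two such steps.

The chain amine change also depends on the aryl group, as a 2.1-fold higher number from compound 1 to compound 4 (0.32 log units; beyond the scatter) runs opposite to the step seen with 3,4-dichlorophenyl: the same change on two cores in this assay, a 2.3-fold lower number (0.36 log units; beyond the scatter) from compound 2 to compound 3 and a 2.1-fold higher number (0.32 log units; beyond the scatter) from compound 1 to compound 4, 4.7-fold (0.67 log units) apart, beyond the scatter of two such steps.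

Across these four compounds, the aryl group and chain amine therefore cannot be treated as independent changes.

Going by these compounds, it remains open whether this dependence extends to other aryl groups at this position, such as 4-fluorophenyl. The same question applies to other chain amines, such as morpholin-4-yl or dimethylamino.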